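A few compounds are considered here, and "the series" means these few. Any claim that something is new, unique, unknown or untested is made for them only; others in the source may bear on it.

Compound 1 `CCN(CC)CN1C(=O)/C(=N/NC(N)=S)c2cc(Cl)ccc21` is the starting point of this account. In an ADME assay on HeLa cells (Homo sapiens) for cytotoxicity (a lower number here means that less compound is tolerated, a higher number that more compound is tolerated), compound 1 gives > 100000 nM, which is a limit of the assay and not a number. Compound 2 `CCN(CC)CN1C(=O)/C(=N/NC(N)=S)c2ccccc21` differs from compound 1 in having hydrogen in place of chloro on an aromatic carbon. In this assay compound 2 gives > 100000 nM, again a limit. Because (the limit of > 100000 nM in this assay, at which 2 of the 3 values shown sit), the step that the two limits leave unreadable from compound 1 to compound 2 cannot be read. Compound 3 `CCN(CC)CN1C(=O)/C(=N/NC(=S)Nc2ccccc2)c2ccccc21` carries phenyl in place of hydrogen on an amide-type nitrogen relative to compound 2, and in this assay compound 3 gives 10800 nM. Within the data shown here, the step of an at least 9.2-fold lower number from compound 2 to compound 3 (0.96 log units; beyond the scatter) is the one measured change with a readable size here.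

The compound not yet measured is compound 4 `CCN(CC)CN1C(=O)/C(=N/NC(=S)Nc2ccc(C)cc2)c2cc(Cl)ccc21`. Its difference from compound 1 is 4-methylphenyl in place of hydrogen on an amide-type nitrogen. Among the measured compounds shown here, this change resembles the one from compound 2 to compound 3, since both place an aromatic group on the amide-type nitrogen, and compound 1 stands at the same limit as compound 2. The step from compound 1 to compound 4 is therefore expected to be a lower number, roughly an at least 10-fold lower number from compound 1 to compound 4 (1.00 log units; beyond the scatter), in this assay. Compound 4 is expected to give about 10000 nM, with a range from 3000 nM to 50000 nM, in this assay.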

Compound 4, half-maximal cytotoxic concentration: > 100000 nM
Compound 4 ended at the assay's limit; the forecaster's own chance of this, stated with the estimate: 20%; middle value at least 10-fold (1.00 log units) from the limit.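

Among these compounds, compound 4, like compound 1, ends at a limit of the assay and not at a number, so no step from compound 1 to compound 4 can be read in this assay, because the two limits coincide: the limit of > 100000 nM in this assay, at which 3 of the 4 values shown sit. The compounds shown leave open whether 4-methylphenyl in place of hydrogen on the amide-type nitrogen changes the number in this assay at all when the chloro group is present.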